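This account rests on a few compounds, and the source may have more. Where it says the series, first, only, none or still open, it means among the compounds named here.

Three compounds share one core and differ only in the group on the triple-bonded carbon. Compound 1 `CC(C)N1CCc2nc(C#Cc3ccccc3Cl)ccc2C1=O` carries a 2-chlorophenyl, and in an assay on HEK293 cells for displacement of a labelled ligand from metabotropic glutamate receptor 5 (Homo sapiens), with a stated time of 2 h (a lower number here means a stronger inhibitor, a higher number a weaker inhibitor), compound 1 gives 5680 nM. Compound 2 `CC(C)N1CCc2nc(C#Cc3cccnc3)ccc2C1=O` carries a pyridin-3-yl, and in this assay compound 2 gives 19600 nM; the exchange brings a 3.5-fold higher number from compound 1 to compound 2 (0.54 log units; beyond the scatter). Compound 3 `CC(C)N1CCc2nc(C#Cc3cccs3)ccc2C1=O` carries a thiophen-2-yl, and in this assay compound 3 gives 1930 nM; from compound 1 this is a 2.9-fold lower number from compound 1 to compound 3 (0.47 log units; beyond the scatter), and from compound 2 it is a 10-fold lower number from compound 2 to compound 3 (1.01 log units; beyond the scatter). Compound 3 therefore stands lowest of the three numbers, beyond the scatter from both of the others.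

Compound 4 `O=C1c2ccc(C#Cc3cccs3)nc2CCN1C1CCCCC1` keeps the thiophen-2-yl and changes a different place on the core: cyclohexyl in place of isopropyl on an amide-type nitrogen in a ring. None of the three measured steps touches this place; all three concern the group on the triple-bonded carbon, so they say nothing directly about what a cyclohexyl in place of an isopropyl on the amide-type nitrogen does. With no measured comparison to lean on, the step expected for compound 4 in this assay is a 1.2-fold lower number from compound 3 to compound 4 (0.08 log units; within the scatter), which is to say no change beyond the scatter, with wide uncertainty in either direction. Compound 4 is accordingly estimated at 1600 nM, with a range from 500 nM to 5000 nM.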

Compound 4, inhibition constant: 720 nM
Estimate against measurement, compound 4: 2.2-fold (0.35 log units) above; measured number inside the range.
By their numbers in this assay, from the lowest: compound 4; then compound 3; then compound 1; then compound 2.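

The earlier compounds shown here varied only the group on the triple-bonded carbon, and compound 4 shows that the amide-type nitrogen in a ring is also a place where the number in this assay can move: a 2.7-fold lower number from compound 3 to compound 4 (0.43 log units; beyond the scatter). With the thiophen-2-yl held fixed, cyclohexyl in place of isopropyl goes with a stronger inhibitor, so at least on this compound pair the step from 3 heavy atoms and no ring to 6 heavy atoms and a six-membered ring of carbon only does not cost binding. Nothing measured here accounts for this step, so the compounds give no explanation of it.

From the compounds shown here alone, this is a single exchange at this nitrogen, made on the thiophen-2-yl compound, so it remains open whether the same step would appear alongside the 2-chlorophenyl or the pyridin-3-yl. Going by these compounds, it also remains open whether the ring or the carbon count goes with the lower number, and how a tert-butyl, a cyclopentyl, a phenyl or a chain ending in an amine or a carboxylic acid on this nitrogen would compare.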